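The compounds below may be only part of what the source reports. "The series", "measured", "known", "first", "only" and "open" are said of these compounds alone.

Values in a functional assay on M21 cells (Homo sapiens) for antiproliferative activity, read by sulforhodamine B assay, with a stated time of 48 h; a lower number here means a stronger inhibitor, a higher number a weaker inhibitor:
Compound 1 `O=C1NCCN1c1ccc(S(=O)(=O)Nc2ccc(I)cc2)cc1`: 260 nM.
Compound 2 `CCCCCCCc1ccc(NS(=O)(=O)c2ccc(N3CCNC3=O)cc2)cc1`: > 1000 nM, a limit of the assay.
Compound 3 `CC(C)(C)c1ccc(NS(=O)(=O)c2ccc(N3CCNC3=O)cc2)cc1`: > 1000 nM, a limit of the assay.

Going by the values given here, compound 1 carries the only actual number in the set. The other two sit at the limit of > 1000 nM in this assay, at which 2 of the 3 values shown sit.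

Compound 4 `Cc1cc(C)cc(NS(=O)(=O)c2ccc(N3CCNC3=O)cc2)c1` has not been measured. Its change from compound 1 is 3,5-dimethylphenyl in place of 4-iodophenyl on a sulfonamide nitrogen.

The closest evidence is the two measured replacements of iodo, which gave an at least 3.8-fold higher number from compound 1 to compound 2 (0.58 log units; beyond the scatter) with heptyl and an at least 3.8-fold higher number from compound 1 to compound 3 (0.58 log units; beyond the scatter) with tert-butyl. Among the compounds with values here, both steps go towards a weaker inhibitor, and no compound here goes against that. Going by these compounds, both are bounded by a limit, so their true size remains open. Neither step tests the two methyl groups of compound 4, so the read-across is loose.

A move of modest size towards a higher number is therefore expected in this assay. The expected step is a 3.1-fold higher number from compound 1 to compound 4 (0.49 log units; beyond the scatter). For compound 4 the estimated value is 800 nM, with an expected range of 250 nM to 2500 nM.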

Compound 4, half-maximal inhibitory concentration: 63 nM
Compound 4: the middle estimate sits 13-fold (1.10 log units) above what was measured; the whole stated range lies above it.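

In this assay, 3,5-dimethylphenyl in place of 4-iodophenyl on a sulfonamide nitrogen gives a 4.1-fold lower number from compound 1 to compound 4 (0.62 log units; beyond the scatter). Going by these compounds alone, this is the first replacement to go towards a stronger inhibitor, so the iodine is not required for activity at this position, and a carbon-only substituted phenyl can outperform 4-iodophenyl. Compound 2 and compound 3 do not give actual numbers, and the step between them cannot be read: the limit of > 1000 nM in this assay, at which 2 of the 4 values shown sit.

The compounds shown do not separate the effect of losing the iodine from that of adding the two methyl groups. Going by these compounds, whether one methyl group alone, two methoxy groups or an amine on this phenyl ring would keep this level of activity remains open.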